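Replacing the Amide Side Chain with Methoxy: Cytotoxicity Expectation

The compounds below may be only part of what the source reports. "The series", "measured", "known", "first", "only" and "open" are said of these compounds alone.

Measured so far in an ADME assay on BHK cells (Mesocricetus auratus) for cytotoxicity, read by MTT assay, with a stated time of 96 h; a higher number here means that more compound is tolerated, a lower number that less compound is tolerated:
- compound 1, `O=C(CN1CCCC1)Nc1ccc(-c2nc3cc(C(F)(F)F)ccc3[nH]2)cc1`: 29000 nM
- compound 2, `O=C(CCl)Nc1ccc(-c2nc3cc(C(F)(F)F)ccc3[nH]2)cc1`: 22000 nM
- compound 3, `CCN(CC)CC(=O)Nc1ccc(-c2nc3cc(C(F)(F)F)ccc3[nH]2)cc1`: 23000 nM

The three compounds share one core and differ only in the group on the saturated chain carbon bound to the carbonyl carbon. Compound 3 stands second highest of the three numbers in this assay, nearest to compound 2 and furthest from compound 1, yet every step among them lies within the scatter: a 1.3-fold lower number from compound 1 to compound 2 (0.12 log units; within the scatter), a 1.3-fold lower number from compound 1 to compound 3 (0.10 log units; within the scatter) and a 1.0-fold higher number from compound 2 to compound 3 (0.02 log units; within the scatter). In this set, swapping that group has not changed tolerance in any measurable way.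

Compound 4, `COc1ccc(-c2nc3cc(C(F)(F)F)ccc3[nH]2)cc1`, is a different kind of change: methoxy in place of (((diethylamino)methyl)carbonyl)amino on an aromatic carbon. The whole side chain goes and a small group takes its place. Going by the values given here, no measured step covers such a change; the three steps only show that the chain end was not decisive. With the values so close together and no guidance pointing elsewhere, the expected step in this assay is a 1.1-fold higher number from compound 3 to compound 4 (0.04 log units; within the scatter), not beyond the scatter. Compound 4 is therefore estimated at 25000 nM, with a range from 10000 nM to 60000 nM.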

Compound 4, half-maximal cytotoxic concentration: > 100000 nM
Compound 4 was reported as a limit (the forecaster's own chance of this, stated with the estimate: 15%); at least 4.0-fold (0.60 log units) between middle value and limit.
By their numbers in this assay, from the lowest: compounds 2, 3 and 1 (each within the scatter of the next). At a limit, above all of these: compound 4.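

Compound 4 is reported in this assay only as a limit of the assay, not as a number: the limit of > 100000 nM in this assay, at which 1 of the 4 values shown sits.

All three steps to it lie beyond the scatter: an at least 4.3-fold higher number from compound 3 to compound 4 (0.63 log units; beyond the scatter), an at least 4.5-fold higher number from compound 2 to compound 4 (0.65 log units; beyond the scatter) and an at least 3.4-fold higher number from compound 1 to compound 4 (0.53 log units; beyond the scatter). Swapping the end of the chain moved nothing beyond the scatter, whereas replacing the whole amide side chain with methoxy on this aromatic carbon did, so tolerance in these compounds depends on what sits at this position even though it did not depend on the chain end.

The change removes the amide hydrogen, the carbonyl and the chain end all at once, so the compounds shown cannot say which of these parts matters, and the limit leaves the full size of the steps unknown. On these data alone, whether a plain amine, a hydroxy group or a short acetyl amide on this carbon would group with compound 4 or with compound 1, compound 2 and compound 3 stays open.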